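A few compounds are considered here, and "the series" means these few. Any claim that something is new, unique, unknown or untested is made for them only; others in the source may bear on it.

- Compound 1 `COC(=O)N1N=C(c2ccccc2)CC1c1cc(OC)c(OC)c(OC)c1` in a functional assay on A549 cells (Homo sapiens) for antiproliferative activity, read by MTT assay, with a stated time of 48 h; a higher number here means a weaker inhibitor of growth, a lower number a stronger inhibitor of growth: 2880 nM
- Compound 2 `COc1cc(C2CC(c3ccccc3)=NN2C(=O)OCc2ccccc2)cc(OC)c1OC` in this assay: > 10000 nM, a limit of the assay and not a number

Among the compounds with values here, compound 1 holds the only true number so far; the other entry is the limit of > 10000 nM in this assay, at which 1 of the 2 values shown sits. Compound 3 `COC(=O)N1N=C(c2ccc(OC)cc2)CC1c1cc(OC)c(OC)c(OC)c1` keeps the core of compound 1 and changes one thing: methoxy in place of hydrogen on an aromatic carbon. This is methoxy in place of hydrogen on an aromatic carbon, turning phenyl into 4-methoxyphenyl. Within the data shown here, the one measured step is an at least 3.4-fold higher number from compound 1 to compound 2 (0.54 log units; beyond the scatter). It places a phenyl on a saturated chain carbon, at a different part of the molecule, so it bears only loosely on this change. It shows that growth inhibition can respond to a single change, but gives no direction for methoxy. No shift beyond the scatter is therefore expected in this assay. The expected step is a 1.4-fold lower number from compound 1 to compound 3 (0.16 log units; within the scatter). For compound 3 the estimated value is 2000 nM, with an expected range from 400 nM to 9000 nM.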

Compound 3, concentration for 50% growth inhibition: 3400 nM
Compound 3: the middle estimate sits 1.7-fold (0.23 log units) below what was measured; measured number inside the range.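

In this assay, turning phenyl into 4-methoxyphenyl gives a 1.2-fold higher number from compound 1 to compound 3 (0.07 log units; within the scatter). This aromatic carbon therefore accepts a methoxy group with no shift that can be told from the scatter, something the earlier step, made at a different part of the molecule, could not show. This is also the first comparison in the series between two true numbers, whereas compound 2 remains a limit of the assay and not a number: the limit of > 10000 nM in this assay, at which 1 of the 3 values shown sits.

Going by these compounds, a single group at a single carbon says little about the ring as a whole, so it stays open whether an amine or a carboxylic acid on this same aromatic carbon would move the number beyond the scatter. Also open, on these data alone, is whether methoxy on another carbon of this ring would leave growth inhibition just as unchanged.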